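This account rests on a few compounds, and the source may have more. Where it says the series, first, only, none or still open, it means among the compounds named here.

Among the measured compounds shown here, in a functional assay on HepG2 cells (Homo sapiens) for inhibition, read by MTT assay, with a stated time of 72 h (on this read-out higher numbers stand for weaker inhibition and lower numbers for stronger inhibition), compound 2 `N#Cc1ccc(-n2cc(COc3cccc(NC(=O)Nc4ccc(Cl)c(C(F)(F)F)c4)c3)nn2)cc1` gives 2980 nM, the higher of the two numbers measured so far; compound 1 `O=C(Nc1cccc(OCc2cn(-c3ccccc3)nn2)c1)Nc1ccc(Cl)c(C(F)(F)F)c1` gives 1780 nM, and the step of a 1.7-fold higher number from compound 1 to compound 2 (0.22 log units; within the scatter) lies within the scatter. Compound 3 `CC(C)c1cccc(-n2cc(COc3cccc(NC(=O)Nc4ccc(Cl)c(C(F)(F)F)c4)c3)nn2)c1` differs from compound 2 in that (3-isopropylphenyl in place of 4-cyanophenyl on an aromatic nitrogen). For the measured compounds named here, the single measured step touches the same ring but is a smaller exchange, and nothing measured bears directly on a 3-isopropylphenyl group. Going by the values given here, with a within-scatter step as the only guide, compound 3 is expected to land near compound 2, at an estimated 2200 nM, ranging from 900 nM to 5500 nM, which would mean an expected step of a 1.4-fold lower number from compound 2 to compound 3 (0.13 log units; within the scatter).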

Compound 3, half-maximal inhibitory concentration: 3250 nM
Estimate against measurement, compound 3: 1.5-fold (0.17 log units) below; the measured number falls inside the stated range.
By their numbers in this assay, from the lowest: compounds 1, 2 and 3 (each within the scatter of the next).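

The exchange of 4-cyanophenyl for 3-isopropylphenyl on the aromatic nitrogen gives a 1.1-fold higher number from compound 2 to compound 3 (0.04 log units; within the scatter), and adding the isopropyl group alone gives a 1.8-fold higher number from compound 1 to compound 3 (0.26 log units; within the scatter). This ring position has therefore now carried a nitrile and an isopropyl group, and neither step from the compounds compared here goes beyond the scatter. From the compounds shown here alone, whether an amine or a carboxylic acid on this ring would give a step beyond the scatter remains open. Nothing available here offers an explanation for these results.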